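Amides and Ureas on a Shared Core Before Compound 4

A few compounds are considered here, and "the series" means these few. Any claim that something is new, unique, unknown or untested is made for them only; others in the source may bear on it.

Among the three compounds already measured in an assay on HEK293 cells for negative allosteric modulation of metabotropic glutamate receptor 5 (Homo sapiens), read by FLIPR (on this read-out lower numbers stand for stronger inhibition and higher numbers for weaker inhibition), compound 3 `O=C(C1CCC1)N1CC(c2nc(-c3cccc(Cl)c3)no2)C1` is the only one with a number: in this assay compound 3 gives 1500 nM. Compound 1 `CC1CCCC(C(=O)N2CC(c3nc(-c4cccc(Cl)c4)no3)C2)C1` returns only a limit of this assay, > 10000 nM. Compound 2 `O=C(N1CCC(F)CC1)N1CC(c2nc(-c3cccc(Cl)c3)no2)C1` likewise returns only a limit, > 10000 nM. The step of an at least 6.6-fold lower number from compound 1 to compound 3 (0.82 log units; beyond the scatter) and the step of an at least 6.6-fold lower number from compound 2 to compound 3 (0.82 log units; beyond the scatter) both run toward the cyclobutyl amide, and the limit of > 10000 nM in this assay, at which 2 of the 3 values shown sit, caps what can be read from them; the step that the two limits leave unreadable from compound 1 to compound 2 cannot be read at all.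

Compound 4 `CC1CCN(C(=O)N2CC(c3nc(-c4cccc(Cl)c4)no3)C2)C1` has not yet been measured. It differs from compound 3 in one place: 3-methylpyrrolidin-1-yl in place of cyclobutyl on a carbonyl carbon. Like the 3-methylcyclohexyl of compound 1, the incoming group is a 3-methyl-substituted saturated ring, and like the 4-fluoropiperidin-1-yl of compound 2 it joins the carbonyl carbon through a ring nitrogen. Both measured steps that replaced such a group with cyclobutyl lowered the number in this assay by at least a modest amount, so the reverse move, from cyclobutyl to a larger nitrogen-linked ring, is expected to raise it, plausibly back to a limit. Compound 4 is therefore expected to give 8000 nM in this assay, within 2500 nM to 30000 nM. That estimate means a step of a 5.3-fold higher number from compound 3 to compound 4 (0.73 log units; beyond the scatter) that is expected to lie beyond the scatter.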

Compound 4, half-maximal inhibitory concentration: > 10000 nM
Compound 4 was reported as a limit (the forecaster's own chance of this, stated with the estimate: 60%); middle value at least 1.2-fold (0.09 log units) away from the limit.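

In this assay, putting 3-methylpyrrolidin-1-yl in place of cyclobutyl on a carbonyl carbon gives an at least 6.6-fold higher number from compound 3 to compound 4 (0.82 log units; beyond the scatter), so a five-membered ring with 1 hetero atom now joins the 3-methylcyclohexyl of compound 1 and the 4-fluoropiperidin-1-yl of compound 2 on the weaker side of compound 3. Compound 3, with its cyclobutyl, thus remains the only compound shown with a number, and its steps to all three others lie beyond the scatter. How far each of the three replacements falls short stays hidden, and the steps among compound 1, compound 2 and compound 4 cannot be read, because the values stop at one limit: the limit of > 10000 nM in this assay, at which 3 of the 4 values shown sit.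

The change from compound 3 to compound 4 alters the ring, adds a methyl and brings in a ring nitrogen all at once, so the compounds shown do not say which of these matters. A cyclopentyl amide and an unsubstituted pyrrolidin-1-yl urea on the same carbonyl carbon would pull these apart, and a cyclopropyl amide would show whether the number improves further with a still smaller carbon ring.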